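A few compounds are considered here, and "the series" means these few. Any claim that something is new, unique, unknown or untested is made for them only; others in the source may bear on it.

Working notes on a functional assay on THP-1 cells (Homo sapiens) for cytotoxicity, read by MTT assay, with a stated time of 24 h; on this read-out higher numbers stand for weaker inhibition and lower numbers for stronger inhibition. Of the compounds shown here, two on the shared core have been measured so far: compound 1 (`COc1cc(/C=C2\CN(C)C/C(=C\c3ccccc3F)C2=O)cc(OC)c1`) gives 1170 nM, and compound 2 (`COc1cc(/C=C2\CN(C)C/C(=C\c3ccc(F)cc3)C2=O)cc(OC)c1`) gives 5040 nM, the higher of the two numbers. Next is compound 3 (`COc1cc(/C=C2\CN(C)C/C(=C\c3ccc(Cl)cc3)C2=O)cc(OC)c1`), which differs from compound 2 by chloro in place of fluoro on an aromatic carbon. Within the data shown here, only one measured step bears on this change, a 4.3-fold higher number from compound 1 to compound 2 (0.63 log units; beyond the scatter). That modest step alters where the fluoro sits, not which halogen is present, so it is indirect evidence. It does show that a change on this phenyl can move the number beyond the scatter. Among the measured compounds shown here, no measured step exchanges one halogen for another, so no step beyond the scatter is expected, with a slight lean towards a lower number. The expected step is a 1.4-fold lower number from compound 2 to compound 3 (0.16 log units; within the scatter). Compound 3 is estimated at 3500 nM, within an expected range of 1500 nM to 9000 nM.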

Compound 3, half-maximal inhibitory concentration: 5860 nM
The estimate for compound 3 lay 1.7-fold (0.22 log units) below the measured number, and the stated range covers the measured number.
By their numbers in this assay, from the lowest: compound 1; then compounds 2 and 3 (each within the scatter of the next).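

In this assay, chloro in place of fluoro on this aromatic carbon gives a 1.2-fold higher number from compound 2 to compound 3 (0.07 log units; within the scatter), so this first exchange of one halogen for another at the position stays inside the scatter. The second new step, a 5.0-fold higher number from compound 1 to compound 3 (0.70 log units; beyond the scatter), shows that the 4-chlorophenyl of compound 3, like the 4-fluorophenyl of compound 2, stands apart from the 2-fluorophenyl of compound 1 by a step beyond the scatter, although that step changes both the halogen and its place on the ring. Nothing measured here gives a reason for these numbers.

Open, as far as these compounds go, is whether a 2-chlorophenyl would give a number close to that of the 2-fluorophenyl in compound 1. Also open, from the compounds shown here alone, is whether an amine or a carboxylic acid on the same aromatic carbon would move the number beyond the scatter, since only two halogens have been compared there.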